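The source may report more compounds than this note shows. Statements on the series, on what has been measured and on what is new or still open speak of the compounds shown alone.

Of the compounds shown here, three on a shared core have been measured so far, differing only in the group on the carbonyl carbon of the ring amide. Compound 1 `CCCCNc1nc(N)nc2c1CN(C(C)=O)CC2` gives 0.5 uM in an assay on HEK293 cells for agonist activity at Toll-like receptor 8 (Homo sapiens), read by a luciferase reporter, with a stated time of 6 h (a lower number here means that less compound is needed, a higher number that more compound is needed for the effect), compound 2 `CCCCNc1nc(N)nc2c1CN(C(=O)C1CCC1)CC2` gives 0.4 uM in this assay, and compound 3 `CCCCNc1nc(N)nc2c1CN(C(=O)c1ccccn1)CC2` gives 2.9 uM in this assay. Compound 3 therefore stands with the highest of the three numbers: the steps of a 5.8-fold higher number from compound 1 to compound 3 (0.76 log units; beyond the scatter) and a 7.3-fold higher number from compound 2 to compound 3 (0.86 log units; beyond the scatter) both lie beyond the scatter, while the step of a 1.3-fold lower number from compound 1 to compound 2 (0.10 log units; within the scatter) does not.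

Compound 4 `CCCCNc1nc(N)nc2c1CN(C(=O)c1cc(C)on1)CC2` is the next step from compound 3: 5-methyl-1,2-oxazol-3-yl in place of pyridin-2-yl on a carbonyl carbon. Within the data shown here, no measured step swaps one aromatic ring for another, so the two steps that bear on it only show that an aromatic group on this carbonyl carbon raised the number relative to a small alkyl. Compound 4 keeps an aromatic group there, so compound 4 is expected to stay near compound 3, with a step of a 1.2-fold lower number from compound 3 to compound 4 (0.06 log units; within the scatter) that is expected to fall within or only just beyond the scatter in this assay. The estimate for compound 4 is 2.5 uM, within a range from 0.8 uM to 8 uM.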

Compound 4, minimum effective concentration: 0.4 uM
Beside the measured number, compound 4's estimate is 6.3-fold (0.80 log units) above it, and the stated range ends above it.
By their numbers in this assay, from the lowest: compounds 2, 4 and 1 (each within the scatter of the next); then compound 3.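

In this assay, among these compounds, the change from pyridin-2-yl to 5-methyl-1,2-oxazol-3-yl on this carbonyl carbon gives a 7.3-fold lower number from compound 3 to compound 4 (0.86 log units; beyond the scatter) and so shows that one aromatic ring can differ from another at this place, which the earlier compounds could not show. The alkyl comparisons, no change at the digits printed from compound 2 to compound 4 (within the scatter) and a 1.3-fold lower number from compound 1 to compound 4 (0.10 log units; within the scatter), place this aromatic group level with cyclobutyl and methyl, so among these four compounds the higher number goes with pyridin-2-yl alone and not with aromatic groups in general. Nothing at hand accounts for the difference between the two rings.

The step changes ring size, hetero atoms and the methyl together, and these cannot be told apart here. Going by these compounds, how phenyl, pyridin-3-yl or 1,2-oxazol-3-yl without its methyl would read remains open.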